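The source may report more compounds than this note shows. Statements on the series, on what has been measured and on what is new or still open speak of the compounds shown alone.

Compound 1, `CCCSc1nc(N)c2nc(O)n(Cc3ccccc3)c2n1`, is the reference point of this account. Its activity was read in a functional assay (spleen, spleen) for activation, with Mus musculus as the target (a higher number here means that more compound is needed for the effect, a lower number that less compound is needed), where compound 1 gives 0.01 uM. Among the measured compounds shown here, that is the lowest of the two numbers measured so far. For the measured compounds named here, the only other measured compound, compound 2, `Nc1ncnc2c1nc(O)n2Cc1ccc(Cl)cc1`, gives in this assay a value of 10 uM, which stands far above the number for compound 1, beyond the scatter of repeated measurements. Compound 2 differs from compound 1 in more than one place, so nothing more than those two values can be drawn from the comparison.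

The next compound, compound 3, `CCNc1nc(N)c2nc(O)n(Cc3ccccc3)c2n1`, has not yet been measured. Compared with compound 1 the change is this: ethylamino in place of propylsulfanyl on an aromatic carbon. Going by the values given here, no measured pair in this set makes this exact change, so the size of the step rests on judgement alone. The step from compound 1 to compound 3, a 3.0-fold higher number from compound 1 to compound 3 (0.48 log units; beyond the scatter), is expected to be a small loss, not far beyond the scatter. Compound 3 is therefore estimated to give in this assay a minimum effective concentration of about 0.03 uM, within a range from 0.005 uM to 0.3 uM.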

Compound 3, minimum effective concentration: 1 uM
For compound 3 the middle estimate is 33-fold (1.52 log units) below the measured one; the measured number lies above the stated range.
By their numbers in this assay, from the lowest: compound 1; then compound 3; then compound 2.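

In this assay, replacing propylsulfanyl with ethylamino on the aromatic carbon between two ring nitrogen atoms is a large step (a 100-fold higher number from compound 1 to compound 3 (2.00 log units; beyond the scatter)). This shows that the group at this position strongly affects the read-out, which the earlier pair could not show, since its two compounds differ in more than one place. Among the compounds shown here, the single exchange changes several things at once, as sulfur gives way to nitrogen, the chain becomes shorter and a hydrogen-bond donor enters, and no measurement at hand gives a reason for the size of the step.

The compounds shown leave open whether the step follows the change of atom or the change of chain, a question that ethylsulfanyl or propylamino at this position would help to separate. They also leave open how far the position tolerates other groups, such as a longer chain like butylsulfanyl, a simple methoxy group or a dimethylamino group, and whether a step of this size would recur on a core carrying a different group on the benzyl ring.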